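Replacing the aryl group of compound 3

The source may hold more compounds than are shown below. What is called first, only, known or untested is meant among the compounds shown, and "the series" means these compounds.

Measured in a functional assay on A549 cells (Homo sapiens) for antiproliferative activity, read by MTT assay, with a stated time of 72 h; a higher number here means a weaker inhibitor, a lower number a stronger inhibitor:
Compound 1 `COc1cc(-n2cnc3ccc(-c4ccccc4Cl)cc32)cc(OC)c1OC`: > 10000 nM, a limit of the assay
Compound 2 `COc1cc(-n2cnc3ccc(-c4ccc([N+](=O)[O-])cc4)cc32)cc(OC)c1OC`: 8940 nM
Compound 3 `COc1cc(-n2cnc3ccc(-c4cccc(N)c4)cc32)cc(OC)c1OC`: 640 nM

Compound 3 has the lowest number shown. The next case is compound 4 `COc1ccc(-c2ccc3ncn(-c4cc(OC)c(OC)c(OC)c4)c3c2)cc1`, with 4-methoxyphenyl in place of 3-aminophenyl on an aromatic carbon. Within the data shown here, two measured steps bear on this, both large: a 14-fold lower number from compound 2 to compound 3 (1.15 log units; beyond the scatter) and an at least 15-fold lower number from compound 1 to compound 3 (1.19 log units; beyond the scatter). Both bring 3-aminophenyl in, and its departure here points the other way, towards a higher number, though a smaller size is expected. In this assay the expected change is a 3.1-fold higher number from compound 3 to compound 4 (0.49 log units; beyond the scatter). The estimate for compound 4 is 2000 nM, with an expected range from 400 nM to 9000 nM.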

Compound 4, half-maximal inhibitory concentration: > 10000 nM
Compound 4 was reported as a limit; the forecaster's own chance of this, stated with the estimate: 15%; middle value at least 5.0-fold (0.69 log units) from the limit.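

In this assay, 4-methoxyphenyl gives back all that 3-aminophenyl gained, with an at least 15-fold higher number from compound 3 to compound 4 (1.19 log units; beyond the scatter), so three different aryl groups now fall well short of 3-aminophenyl at this carbon. Methoxy in place of nitro gives an at least 1.1-fold higher number from compound 2 to compound 4 (0.04 log units; that floor lies within the scatter), which separates neither compound. Compound 4 stands at a limit of the assay, and its step from compound 1 cannot be read: the limit of > 10000 nM in this assay, at which 2 of the 4 values shown sit.

On these data alone, whether the amine or its place on the ring matters remains open. A 4-aminophenyl or 3-methoxyphenyl group would separate the two.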